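Chloro for Fluoro, Repeated on a Second Core

The compounds below may be only part of what the source reports. "The series", "measured", "known", "first", "only" and "open" are said of these compounds alone.

Of the compounds shown here, three have been tested in an ADME assay on HEK-293T cells (Homo sapiens) for cytotoxicity, read by MTT assay, with a stated time of 24 h; a higher number here means that more compound is tolerated, a lower number that less compound is tolerated. Compound 1 `O=S(=O)(c1ccc(F)cc1)n1c(-c2cn(-c3ccccc3)nc2-c2ccc(F)cc2)nc2ccccc21` gives 218000 nM. Compound 2 `O=S(=O)(c1ccc(Cl)cc1)n1c(-c2cn(-c3ccccc3)nc2-c2ccc(F)cc2)nc2ccccc21` differs from it by chloro in place of fluoro on an aromatic carbon and gives 93100 nM, a step of a 2.3-fold lower number from compound 1 to compound 2 (0.37 log units; beyond the scatter). Compound 3 `O=S(=O)(c1ccc(F)cc1)n1c(-c2cn(-c3ccccc3)nc2-c2ccc(C(F)(F)F)cc2)nc2ccccc21` has a different core, differing from compound 1 by trifluoromethyl in place of fluoro on an aromatic carbon. Compound 3 gives 157000 nM, a step of a 1.4-fold lower number from compound 1 to compound 3 (0.14 log units; within the scatter).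

Compound 4 `O=S(=O)(c1ccc(Cl)cc1)n1c(-c2cn(-c3ccccc3)nc2-c2ccc(C(F)(F)F)cc2)nc2ccccc21` has not been measured. It differs from compound 3 by chloro in place of fluoro on an aromatic carbon. For the measured compounds named here, this is the same change as the one from compound 1 to compound 2, and the two place descriptions agree word for word, so it is the same change carried onto the second core.

For compound 4 the expected step is a 2.3-fold lower number from compound 3 to compound 4 (0.36 log units; beyond the scatter). Going by the values given here, this rests on the single earlier example of the change, a 2.3-fold lower number from compound 1 to compound 2 (0.37 log units; beyond the scatter), and on the difference between the two cores having shifted the number only within the scatter, a 1.4-fold lower number from compound 1 to compound 3 (0.14 log units; within the scatter). Compound 4 is therefore estimated at 68000 nM, with a likely range from 34000 nM to 136000 nM.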

Compound 4, half-maximal cytotoxic concentration: 75300 nM
Estimate against measurement, compound 4: 1.1-fold (0.04 log units) below, and the stated range covers the measured number.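

In this assay, chloro in place of fluoro gives a 2.1-fold lower number from compound 3 to compound 4 (0.32 log units; beyond the scatter), so the step seen on the first core also appears on the second, at a matching size: the same change on two cores in this assay, a 2.3-fold lower number (0.37 log units; beyond the scatter) from compound 1 to compound 2 and a 2.1-fold lower number (0.32 log units; beyond the scatter) from compound 3 to compound 4, 1.1-fold (0.05 log units) apart, within the scatter of two such steps

Trifluoromethyl in place of fluoro, now on the chloro-bearing compounds, gives a 1.2-fold lower number from compound 2 to compound 4 (0.09 log units; within the scatter), which stays within the scatter as it did before: the same change on two cores in this assay, a 1.4-fold lower number (0.14 log units; within the scatter) from compound 1 to compound 3 and a 1.2-fold lower number (0.09 log units; within the scatter) from compound 2 to compound 4, 1.1-fold (0.05 log units) apart, within the scatter of two such steps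

Together, these steps show that in these four compounds the two changes carry over from one core to the other without their sizes visibly depending on the partner group, but with only one pair per core, they do not show that this would hold on a third core, and they do not explain why chloro lowers the number.

The compounds shown leave open whether bromo, methoxy or an amine on the same aromatic carbon would follow the chloro step or depart from it. They also leave open whether a similar step would appear in cell types other than the one tested here.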